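Citrate-site ligands: swapping methoxyphenyl for dimethylphenyl

The source may hold more compounds than are shown below. What is called first, only, known or untested is meant among the compounds shown, and "the series" means these compounds.

Measured compounds:
compound 1, `O=C(O)CC(O)(CSCCCCCc1ccc(Cl)cc1Cl)C(=O)O`, 6800 nM
compound 2, `COc1ccc(CCCCCCSCC(O)(CC(=O)O)C(=O)O)cc1`, 280000 nM

For the measured compounds named here, in an assay on isolated protein for inhibition of ATP-citrate synthase (Rattus norvegicus) (on this read-out higher numbers stand for weaker inhibition and lower numbers for stronger inhibition), compound 2 gives 280000 nM, the highest of the two numbers known; compound 1 in this assay gives 6800 nM, a far lower number, and the gap between them lies well beyond the scatter. Compound 3, `Cc1ccc(CCCCCCSCC(O)(CC(=O)O)C(=O)O)c(C)c1`, differs from compound 2 in one place: 2,4-dimethylphenyl in place of 4-methoxyphenyl on a saturated chain carbon, six bonds along the chain from a sulfur. Going by the values given here, no pair of measured compounds isolates this change, so the step can only be judged from the two values shown. Compound 1 carries a 2,4-dichlorophenyl group on a shorter chain and gives 6800 nM, and the 2,4-dimethylphenyl of compound 3 echoes that substitution pattern, so a step toward a lower number is expected, estimated at a 7.0-fold lower number from compound 2 to compound 3 (0.85 log units; beyond the scatter), clearly beyond the scatter though short of compound 1. For compound 3 the expected inhibition constant is 40000 nM, with a range from 10000 nM to 150000 nM.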

Compound 3, inhibition constant: 160000 nM
Estimate against measurement, compound 3: 4.0-fold (0.60 log units) below; the measured number lies above the stated range.
By their numbers in this assay, from the lowest: compound 1; then compounds 3 and 2 (each within the scatter of the next).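

In this assay, replacing 4-methoxyphenyl with 2,4-dimethylphenyl gives a 1.8-fold lower number from compound 2 to compound 3 (0.24 log units; within the scatter) and so does not separate the two groups at this place, on a saturated chain carbon, six bonds along the chain from a sulfur. The entering group has no hydrogen-bond acceptor where the leaving group has one, yet this exchange produces no step beyond the scatter. Nothing measured here bears on the reason for this result and the pair gives only the size of the step.

Compound 3 differs from compound 1 in more than one place, so the compounds shown do not assign the gap to the ring substituents or to the chain. From the compounds shown here alone, how a 2,4-dichlorophenyl on this same chain, a pyridine ring or a longer chain would read remains open.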